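Swapping the benzyl arm of compound 1 for cyclopropylmethyl

This account rests on a few compounds, and the source may have more. Where it says the series, first, only, none or still open, it means among the compounds named here.

Of the compounds shown here, three built on one shared core have been measured in an assay on isolated protein (artery, Oryctolagus cuniculus) with Substance-P receptor (Homo sapiens) as the target; a lower number here means tighter binding, a higher number weaker binding. Compound 1 `O=C1CCC(CCN2CC(N3CCNCC3)C2)(c2ccc(Cl)c(Cl)c2)CN1Cc1ccccc1` carries a piperazin-1-yl group on a saturated ring carbon and gives 5.01 nM, the highest number of the three. Compound 2 `O=C1CCC(CCN2CC(N3CCC(O)CC3)C2)(c2ccc(Cl)c(Cl)c2)CN1Cc1ccccc1` gives 0.0794 nM, and compound 3 `O=C1CCC(CCN2CC(N3CCCC(O)C3)C2)(c2ccc(Cl)c(Cl)c2)CN1Cc1ccccc1` gives 2 nM. Every measured step concerns that same saturated ring carbon: a 63-fold lower number from compound 1 to compound 2 (1.80 log units; beyond the scatter), a 2.5-fold lower number from compound 1 to compound 3 (0.40 log units; beyond the scatter) and a 25-fold higher number from compound 2 to compound 3 (1.40 log units; beyond the scatter).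

Compound 4 `O=C1CCC(CCN2CC(N3CCNCC3)C2)(c2ccc(Cl)c(Cl)c2)CN1CC1CC1` differs from compound 1 at a different place: cyclopropyl in place of phenyl on a saturated chain carbon bound to an amide-type nitrogen in a ring. For the measured compounds named here, none of the measured steps touches this position, so none of them bears directly on the change; they show only that the series can move over a wide span when a single group is exchanged. With no measured guide for this position, a cautious expectation is a step in this assay that stays small, with a slight lean toward a higher number, and the estimated step is a 2.0-fold higher number from compound 1 to compound 4 (0.30 log units; within the scatter). For compound 4 the expected value is 10 nM, with a likely range from 2.5 nM to 40 nM.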

Compound 4, dissociation constant: 12.6 nM
For compound 4 the middle estimate is 1.3-fold (0.10 log units) below the measured one, within the range that was stated.
By their numbers in this assay, from the lowest: compound 2; then compound 3; then compound 1; then compound 4.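

Exchanging the benzyl arm for cyclopropylmethyl gives a 2.5-fold higher number from compound 1 to compound 4 (0.40 log units; beyond the scatter) in this assay, the first view of what this position does, and the step shows that changes here register in the read-out. The change is modest, however: cyclopropyl, with 3 heavy atoms, takes the place of phenyl, with 6, and among these two compounds an aromatic ring on this arm is not needed for binding to stay clearly measurable, as compound 4 still gives 12.6 nM with the piperazin-1-yl group kept. Nothing available here explains why the number rises with this swap.

As far as these compounds go, it remains open whether the same exchange would give a step of similar size on compound 2, which carries 4-hydroxypiperidin-1-yl and has the lowest number so far, or whether the two changes would not simply add up. Also open, from the compounds shown here alone, is how a small methyl group, a longer arm such as 2-phenylethyl or a ring containing nitrogen such as pyridin-2-ylmethyl would read at this position.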